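Replacing the morpholine amide of compound 2 with an acrylamide chain

The compounds below may be only part of what the source reports. "The series", "measured", "known", "first", "only" and "open" are said of these compounds alone.

Measured compounds and their values in an in vitro assay on Sf9 cells for inhibition of 17-beta-hydroxysteroid dehydrogenase type 1 (Homo sapiens), tested at 1 uM; a higher number here means a stronger effect of the compound at the concentration tested, a lower number a weaker effect:
compound 1, `O=C(c1c(O)ccc2cc(-c3cccc(O)c3)ccc12)N1CCCCC1`, 73%
compound 2, `O=C(c1c(O)ccc2cc(-c3cccc(O)c3)ccc12)N1CCOCC1`, 62%
compound 3, `CNC(=O)c1cc2cc(-c3cccc(O)c3)ccc2cc1O`, 18%

Compound 2 stands second highest of the three numbers. Its nearest neighbour is compound 1, which sits above it by a number 11 percentage points lower from compound 1 to compound 2 (beyond the scatter), a step that exchanges one saturated ring amide for another on the carbonyl carbon. Compound 3, which carries a methylcarbamoyl group at a different position of the shared core, gives 18%, far below compound 2.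

Compound 4, `CNC(=O)/C=C/c1c(O)ccc2cc(-c3cccc(O)c3)ccc12`, is not yet measured. Its change from compound 2 is 2-(methylcarbamoyl)ethenyl in place of (morpholin-4-yl)carbonyl on an aromatic carbon. Going by the values given here, no measured step matches this change: the only recorded step, from compound 1 to compound 2, swaps one cyclic amine within the amide and is modest. Among the compounds with values here, compound 3 shows that a small secondary amide on the core can go with a low number, though its amide sits elsewhere and no step to compound 2 is recorded. The move from a ring amide directly on the aromatic carbon to a chain bearing the amide is larger than any step seen, so a drop beyond the scatter is expected, of size a number 22 percentage points lower from compound 2 to compound 4 (beyond the scatter). Compound 4 is therefore estimated at 40%, within a range from 15% to 65%.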

Compound 4, a percentage reported as inhibition, at one concentration (the size of the read-out at that concentration, not a potency): 58%
Compound 4: the middle estimate sits 18 percentage points below what was measured, and the stated range covers the measured number.
By their numbers in this assay, from the lowest: compound 3; then compounds 4 and 2 (each within the scatter of the next); then compound 1.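

Going by these compounds alone, the earlier compounds showed only one saturated ring amide exchanged for another on this aromatic carbon, ortho to a hydroxy group, so they left open whether the ring or the directly attached carbonyl had to stay. In this assay, replacing (morpholin-4-yl)carbonyl with 2-(methylcarbamoyl)ethenyl gives a number 4 percentage points lower from compound 2 to compound 4 (within the scatter), so at this position an open chain with no ring reads the same as the morpholine amide within the scatter, even though the carbonyl no longer sits on the aromatic carbon. The (piperidin-1-yl)carbonyl group still stands apart from the chain, with a number 15 percentage points lower from compound 1 to compound 4 (beyond the scatter), but no measurement bears on why either exchange gives the size of step it does.

As far as these compounds go, it remains open whether the number depends on the double bond of the chain, which a saturated ethyl link would test, or on the methylcarbamoyl end. From the compounds shown here alone, how a carboxylic acid, an amine or a piperidin-1-yl amide at the end of the same chain, or a longer chain, would read at this position is equally open.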